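From 4-fluorophenyl to 3-cyanophenyl on the sulfonyl sulfur

The source may hold more compounds than are shown below. What is called first, only, known or untested is meant among the compounds shown, and "the series" means these compounds.

Compound 1 `O=C(CCl)Nc1ccc(Cl)cc1NS(=O)(=O)c1c(F)cccc1F`, compound 2 `O=C(CCl)Nc1ccc(Cl)cc1NS(=O)(=O)c1cc(Cl)cc(Cl)c1`, compound 3 `O=C(CCl)Nc1ccc(Cl)cc1NS(=O)(=O)c1ccc(F)cc1` and compound 4 `N#Cc1cccc(S(=O)(=O)Nc2cc(Cl)ccc2NC(=O)CCl)c1` share one core and differ only in the group on the sulfonyl sulfur. In an ADME assay on MT4 cells (Homo sapiens) for cytotoxicity, with a stated time of 5 days (on this read-out lower numbers stand for higher toxicity in this test and higher numbers for lower toxicity in this test), compound 1 gives 175000 nM. Compound 2 gives > 291000 nM, which is a limit of the assay and not a number. Compound 3 offers no number as a starting point, and its result in this assay stands as "not determined" (no result reported).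

The change to follow is 3-cyanophenyl in place of 4-fluorophenyl on a sulfonyl sulfur. For the measured compounds named here, the one measured step that bears on it is an at least 1.6-fold higher number from compound 1 to compound 2 (0.22 log units; that floor lies within the scatter), with 3,5-dichlorophenyl in place of 2,6-difluorophenyl at the same place. This is an exchange of the same kind between other groups, so it is only an indirect guide. With no value for compound 3, the step to compound 4 cannot be anchored, and the level of compound 1 and compound 2 has to serve instead. No step beyond the scatter is expected in this assay, and no direction can be assigned. Compound 4 is estimated at 190000 nM, with an expected range of 85000 nM to 330000 nM.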

Compound 4, half-maximal cytotoxic concentration: > 155000 nM
Compound 4: only a limit was reported; the forecaster's own chance of this, stated with the estimate: 35%; the middle value does not contradict the limit.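

In this assay compound 4 gives > 155000 nM, which is a limit of the assay and not a number. The steps from compound 1 and from compound 2 to compound 4 therefore cannot be read. The compounds shown leave open where compound 3 and compound 4 stand, and whether any exchange on the sulfonyl sulfur moves this read-out beyond the scatter.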